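Aryl change from compound 3 to compound 4

The source may hold more compounds than are shown below. What is called first, only, known or untested is meant among the compounds shown, and "the series" means these compounds.

Three measured compounds share one core and differ in the aryl group on a saturated chain carbon bound to a nitrogen on an aromatic ring. In a functional assay on CCRF-CEM cells (Homo sapiens) for antiproliferative activity, with a stated time of 72 h (on this read-out lower numbers stand for stronger inhibition and higher numbers for weaker inhibition), compound 1 (`OC[C@H]1O[C@@H](n2cnc3c(NCc4ccc(F)cc4)ncnc32)[C@H](O)[C@@H]1O`) gives 1250 nM, compound 2 (`OC[C@H]1O[C@@H](n2cnc3c(NCc4ccc(Cl)cc4)ncnc32)[C@H](O)[C@@H]1O`) gives 10200 nM and compound 3 (`COc1cccc(CNc2ncnc3c2ncn3[C@@H]2O[C@H](CO)[C@@H](O)[C@H]2O)c1`) gives 7600 nM. Compound 3 is not separated from compound 2, the step being a 1.3-fold lower number from compound 2 to compound 3 (0.13 log units; within the scatter). Compound 1 alone stands apart, with a 6.1-fold higher number from compound 1 to compound 3 (0.78 log units; beyond the scatter).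

The unmeasured compound 4 (`OC[C@H]1O[C@@H](n2cnc3c(NCc4ccc(F)c(F)c4F)ncnc32)[C@H](O)[C@@H]1O`) has 2,3,4-trifluorophenyl in place of 3-methoxyphenyl at that same place (2,3,4-trifluorophenyl in place of 3-methoxyphenyl on a saturated chain carbon bound to a nitrogen on an aromatic ring). For the measured compounds named here, no measured step leads to this group directly. Going by the values given here, the closest evidence is compound 1, the only measured compound bearing fluorine. Its two measured steps are both modest and both lead away from it to higher numbers: a 6.1-fold higher number from compound 1 to compound 3 (0.78 log units; beyond the scatter) and, with chloro in place of fluoro, an 8.2-fold higher number from compound 1 to compound 2 (0.91 log units; beyond the scatter). Among the compounds with values here, the trend rests on this single compound, and no compound with several fluorines has been measured, so the expectation stays wide. A modest move to a lower number in this assay is expected, and the expected step is a 3.0-fold lower number from compound 3 to compound 4 (0.48 log units; beyond the scatter). For compound 4 the estimated value is 2500 nM, with an expected range of 700 nM to 9000 nM.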

Compound 4, half-maximal inhibitory concentration: 58200 nM
For compound 4 the middle estimate is 23-fold (1.37 log units) below the measured one; the measured number lies above the stated range.
By their numbers in this assay, from the lowest: compound 1; then compounds 3 and 2 (each within the scatter of the next); then compound 4.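

Fluorine on the aryl group does not by itself go with a low number in this assay: the step of a 47-fold higher number from compound 1 to compound 4 (1.67 log units; beyond the scatter) is the largest in the series and puts two fluorine-bearing compounds at opposite ends of the four values. Compound 4 also stands clear of the two compounds that could not be separated earlier, with a 7.7-fold higher number from compound 3 to compound 4 (0.88 log units; beyond the scatter) and a 5.7-fold higher number from compound 2 to compound 4 (0.76 log units; beyond the scatter) as its steps, so this position on a saturated chain carbon bound to a nitrogen on an aromatic ring carries a wider spread than the first three compounds showed. Nothing available on these compounds bears on why 2,3,4-trifluorophenyl gives the highest number here.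

With only 4-fluorophenyl and 2,3,4-trifluorophenyl as fluorinated groups, the number of fluorines and their places on the ring cannot be told apart as the source of the gap between compound 1 and compound 4. A plain phenyl group or a difluorophenyl group at this place would show whether the values change stepwise or whether 4-fluorophenyl is a lone low point.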